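Nitrogen substituent change in a platelet inhibition series

A few compounds are considered here, and "the series" means these few. Any claim that something is new, unique, unknown or untested is made for them only; others in the source may bear on it.

Compound 1 `CCOC(=O)c1ccc(-c2nn(Cc3ccc(F)cc3)c3ccccc23)cc1` and compound 2 `CCOC(=O)c1ccc(-c2nn(Cc3ccccn3)c3ccccc23)cc1` share one core and differ only in the group on the aromatic nitrogen. In a functional assay on cells (Platelet, Homo sapiens) for inhibition (on this read-out lower numbers stand for stronger inhibition and higher numbers for weaker inhibition), compound 1 gives 190 nM, and in this assay compound 2 gives 290 nM. The step of a 1.5-fold higher number from compound 1 to compound 2 (0.18 log units; within the scatter) is within the scatter, so compound 2 stands level with compound 1 on the two numbers shown. Compound 3 `CCOC(=O)c1ccc(-c2nn(-c3ccco3)c3ccccc23)cc1` carries furan-2-yl in place of (pyridin-2-yl)methyl on an aromatic nitrogen. For the measured compounds named here, no measured step places an aromatic ring directly on this nitrogen without the saturated carbon between, so the single step seen, a 1.5-fold higher number from compound 1 to compound 2 (0.18 log units; within the scatter), bears only loosely: exchanging one aromatic ring for another at this position left the number essentially unchanged. The change to compound 3 is larger, so a wider range is expected. Compound 3 is estimated at 400 nM in this assay, with a range from 100 nM to 1600 nM. The expected step is a 1.4-fold higher number from compound 2 to compound 3 (0.14 log units; within the scatter), a mild weakening that may still fall within the scatter.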

Compound 3, half-maximal inhibitory concentration: 340 nM
Compound 3: middle estimate off by 1.2-fold (0.07 log units), on the high side; the range from low to high includes it.
By their numbers in this assay, from the lowest: compounds 1, 2 and 3 (each within the scatter of the next).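

In this assay, furan-2-yl directly on the aromatic nitrogen in place of (pyridin-2-yl)methyl gives a 1.2-fold higher number from compound 2 to compound 3 (0.07 log units; within the scatter), and in place of 4-fluorobenzyl it gives a 1.8-fold higher number from compound 1 to compound 3 (0.25 log units; within the scatter). For the compounds shown here, compounds 1 and 2 both keep a saturated carbon on this nitrogen, so compound 3 adds the first reading without that carbon; all three compounds stand level within the scatter, which shows that this position accepts a five-membered aromatic ring with 1 hetero atom attached directly as well as a six-membered or fluorinated aromatic ring held through a carbon. No supporting measurement is available to account for these numbers.

From the compounds shown here alone, all three compounds carry an aromatic ring at this position, so the effect of a non-aromatic group there, such as an amine on a longer chain, remains open. The ethyl ester is also common to all three, leaving open what a carboxylic acid in its place would do.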